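This account rests on a few compounds, and the source may have more. Where it says the series, first, only, none or still open, it means among the compounds named here.

Compound 1 `COc1cc(C(F)(F)F)cc(SC)c1C(=O)NC1(c2ccc(Cl)cc2)CCCN(C)C1` and compound 3 `COc1cc(C(F)(F)F)cc(SC)c1C(=O)NC1(c2cccc(Cl)c2)CCCN(C)C1` share one core; the two have the same atoms, joined differently (3-chlorophenyl in place of 4-chlorophenyl on a saturated ring carbon). In an assay on cells for inhibition of sodium- and chloride-dependent glycine transporter 1 (Homo sapiens) (a lower number here means that less compound is needed, a higher number that more compound is needed for the effect), compound 1 gives 28 nM, and compound 3 gives 25 nM, a step of a 1.1-fold lower number from compound 1 to compound 3 (0.05 log units; within the scatter). Compound 2 `COc1ccc(C2(NC(=O)c3c(OC)cc(C(F)(F)F)cc3SC)CCCN(C)C2)cc1` is made from compound 1 by one change (methoxy in place of chloro on an aromatic carbon); in this assay compound 2 gives 170 nM, a step of a 6.1-fold higher number from compound 1 to compound 2 (0.78 log units; beyond the scatter). Compound 4 `COc1cccc(C2(NC(=O)c3c(OC)cc(C(F)(F)F)cc3SC)CCCN(C)C2)c1` is made from compound 3 by the same kind of change (methoxy in place of chloro on an aromatic carbon); what differs around the place is that the earlier one sits para to a large group and this one meta to a large group. A step of the same size is expected here, a 5.6-fold higher number from compound 3 to compound 4 (0.75 log units; beyond the scatter), resting on a 6.1-fold higher number from compound 1 to compound 2 (0.78 log units; beyond the scatter). Compound 4 is therefore estimated at 140 nM, between 50 nM and 400 nM.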

Compound 4, half-maximal effective concentration: 110 nM
For compound 4 the middle estimate is 1.3-fold (0.10 log units) above the measured one; measured number inside the range.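

In this assay, methoxy in place of chloro gives (a 4.4-fold higher number from compound 3 to compound 4 (0.64 log units; beyond the scatter)), so the change carries over from one core to the other with a similar step: the same change on two cores in this assay, a 6.1-fold higher number (0.78 log units; beyond the scatter) from compound 1 to compound 2 and a 4.4-fold higher number (0.64 log units; beyond the scatter) from compound 3 to compound 4, 1.4-fold (0.14 log units) apart, within the scatter of two such steps. The two positions of the methoxy cannot be told apart (a 1.5-fold lower number from compound 2 to compound 4 (0.19 log units; within the scatter)), and the step that changes both group and position (a 3.9-fold higher number from compound 1 to compound 4 (0.59 log units; beyond the scatter)) is in keeping with this. These two cores differ only in where the group sits on the phenyl ring, so the result does not show that the step would hold on a core changed elsewhere, nor why the number rises.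

The compounds shown carry only chloro or methoxy on that ring, so a fluoro, a nitrile or an amine in the same place remains open. Also open, from the compounds shown here alone, is whether the step survives when other parts of the shared core change.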